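A few compounds are considered here, and "the series" means these few. Any claim that something is new, unique, unknown or untested is made for them only; others in the source may bear on it.

Measured so far in a functional assay on CHO-K1 cells for antagonist activity at adenosine receptor A1 (Homo sapiens), read by a beta-galactosidase reporter and cAMP accumulation, with stated times of 15 min and 6 h; on this read-out lower numbers stand for stronger inhibition and higher numbers for weaker inhibition: compound 1 `Cc1ccc(-c2nc(N)c3cc(Cc4ccccc4)sc3n2)o1`, 298 nM; compound 2 `Cc1csc(-c2nc(N)c3cc(C(C)c4ccccc4)sc3n2)n1`, 1420 nM; compound 3 `CC(c1ccccc1)c1cc2c(N)nc(-c3cccc(C#N)c3)nc2s1`, 1770 nM.

Within the data shown here, compound 1 gives the lowest of the three numbers in this assay; compound 2 and compound 3 both stand higher, beyond the scatter, but each differs from compound 1 in two places, so no single step separates the aryl change from the side-chain change. Compound 4 `N#Cc1cccc(-c2nc(N)c3cc(Cc4ccccc4)sc3n2)n1` differs from compound 1 by 6-cyanopyridin-2-yl in place of 5-methylfuran-2-yl on an aromatic carbon. Among the measured compounds shown here, the one measured step at the same position, a 1.2-fold higher number from compound 2 to compound 3 (0.10 log units; within the scatter), is within the scatter and is the only evidence bearing on the new aryl group. A small step from compound 1 to compound 4 is therefore expected, a 1.7-fold higher number from compound 1 to compound 4 (0.22 log units; within the scatter), with wide uncertainty. Compound 4 is estimated at 500 nM, range 150 nM to 1800 nM.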

Compound 4, inhibition constant: > 1000 nM
Compound 4 was reported as a limit; the forecaster's own chance of this, stated with the estimate: 5%; at least 2.0-fold (0.30 log units) between middle value and limit.
By their numbers in this assay, from the lowest: compound 1; then compounds 2 and 3 (each within the scatter of the next).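

With the rest of compound 1 kept, 6-cyanopyridin-2-yl in place of 5-methylfuran-2-yl on this aromatic carbon, between two ring nitrogen atoms, gives an at least 3.3-fold higher number from compound 1 to compound 4 (0.52 log units; beyond the scatter) in this assay. Among these compounds, the earlier step at this position, a 1.2-fold higher number from compound 2 to compound 3 (0.10 log units; within the scatter), showed no change beyond the scatter, so this is the first single change here that goes beyond it. Compound 4 carries a limit and not a number, so the step has no upper size: the limit of > 1000 nM in this assay, at which 1 of the 4 values shown sits.

The compounds shown do not separate the change of ring from the nitrile, which a plain pyridin-2-yl group at this carbon would address. From the compounds shown here alone, how an amine on the aryl ring would read also remains open.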